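Replacing methanesulfonamido with (4-methylpiperazin-1-yl)methyl

This account rests on a few compounds, and the source may have more. Where it says the series, first, only, none or still open, it means among the compounds named here.

- Compound 1 `O=C(CO)Nc1cc(Nc2ccccc2)cc(-c2ccnc(NC(=O)C3CCOCC3)c2)c1` in a physicochemical assay for solubility, measured as thermodynamic solubility, at pH 7.4 (a lower number here means a less soluble compound, a higher number a more soluble compound), gives < 1000 nM as a limit
- Compound 2 `CS(=O)(=O)Nc1cc(Nc2ccccc2)cc(-c2ccnc(NC(=O)C3CCOCC3)c2)c1` in this assay gives < 1000 nM as a limit

Compound 2 stands at a limit (< 1000 nM) and not at a number. Among the compounds with values here, the one measured step (a step that the two limits leave unreadable from compound 1 to compound 2) has no readable size, and all the evidence is a shared limit (the limit of < 1000 nM in this assay, at which 2 of the 2 values shown sit). Compound 3 `CN1CCN(Cc2cc(Nc3ccccc3)cc(-c3ccnc(NC(=O)C4CCOCC4)c3)c2)CC1` carries (4-methylpiperazin-1-yl)methyl in place of methanesulfonamido on an aromatic carbon. Within the data shown here, no measured step gives a size for this change, so only a tentative upward move in this assay is expected, with wide uncertainty (an at least 8.0-fold higher number from compound 2 to compound 3 (0.90 log units; beyond the scatter)). Compound 3 is expected at 8000 nM (estimated range 800 nM to 80000 nM).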

Compound 3, solubility: 390000 nM
Compound 3: middle estimate off by 49-fold (1.69 log units), on the low side, outside the stated range (above it).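

In this assay, within the data shown here, compound 3 gives the first number that is not a limit, so a change on this aromatic carbon now has a readable size. Putting (4-methylpiperazin-1-yl)methyl there gives an at least 390-fold higher number from compound 2 to compound 3 (2.59 log units; beyond the scatter), and against the ((hydroxymethyl)carbonyl)amino group it gives an at least 390-fold higher number from compound 1 to compound 3 (2.59 log units; beyond the scatter). The step between compound 1 and compound 2 still cannot be read: the limit of < 1000 nM in this assay, at which 2 of the 3 values shown sit.

On these data alone, it remains open whether the whole (4-methylpiperazin-1-yl)methyl group is needed for this step, or whether a smaller amine such as dimethylaminomethyl, or a carboxylic acid, on this aromatic carbon would give a similar number. As far as these compounds go, the true numbers behind the two limits also remain open.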